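This account rests on a few compounds, and the source may have more. Where it says the series, first, only, none or still open, it means among the compounds named here.

Two pairs of compounds, built on two different cores, share one small change on a phenyl ring. Compound 1 `CC(=O)c1c(NNc2ccc(Cl)cc2)cc(C)oc1=O` carries a chloro group on its aromatic ring, and compound 2 `CC(=O)c1c(NNc2ccc(Br)cc2)cc(C)oc1=O` is the same molecule with bromo in its place; the difference is described as bromo in place of chloro on an aromatic carbon. Both were tested in a functional assay on the whole organism for inhibition, with Rattus norvegicus as the target, read by paw edema, with a stated time of 3 h, at a dose of 50 mg/kg; on this read-out higher numbers stand for more inhibition at the one dose given (going by the name of the read-out) and lower numbers for less inhibition. In this assay compound 1 gives 58.6%, while compound 2 gives 40.4%, so the swap produced a step of a number 18.2 percentage points lower from compound 1 to compound 2 (beyond the scatter).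

Compound 3 `Cc1cc2nn(-c3ccc(Cl)cc3)c(C)c2c(=O)o1` has a different core; how the core of compound 3 differs from the core of compound 1 is not broken down here. In this assay compound 3 gives 56.6%, a number that lies within the scatter of the value of compound 1. Compound 4 `Cc1cc2nn(-c3ccc(Br)cc3)c(C)c2c(=O)o1` has not yet been measured; it differs from compound 3 by bromo in place of chloro on an aromatic carbon, which is the same change that turns compound 1 into compound 2.

Among the compounds with values here, because the only measured example of this change gave a number 18.2 percentage points lower from compound 1 to compound 2 (beyond the scatter), a step of similar size is expected for compound 4, namely a number 14.6 percentage points lower from compound 3 to compound 4 (beyond the scatter). This expectation rests on a single pair on a different core, so it is held loosely. Compound 4 is therefore estimated at 42%, with a likely range from 28% to 56%.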

Compound 4, a percentage reported as inhibition, in the whole organism at one dose (the size of the read-out at that dose, not a potency): 49.5%
The estimate for compound 4 lay 7.5 percentage points below the measured number; the measured number falls inside the stated range.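

Putting bromo in place of chloro on the core of compound 3 gives a number 7.1 percentage points lower from compound 3 to compound 4 (within the scatter) in this assay, so on this core the effect of the change cannot be told apart from the ordinary spread of repeated measurements. Set beside the step on the core of compound 1, the new step does not differ from it by more than the scatter of two such steps allows, so nothing here shows that the core alters what the change does: the same change on two cores in this assay, a number 18.2 percentage points lower (beyond the scatter) from compound 1 to compound 2 and a number 7.1 percentage points lower (within the scatter) from compound 3 to compound 4, 11.1 percentage points apart, within the scatter of two such steps What this does not show is that the change has one fixed size on both cores: only one of the two steps stands clear of the scatter, and two pairs in a single assay at a single dose cannot settle its size or say whether the direction would hold on a third core.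

The compounds shown leave open how other groups on the same aromatic carbon, such as fluoro, methoxy or an amine, would compare with chloro and bromo on either core. They also leave open whether a plain hydrogen at that carbon would read differently from either halogen.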